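The source may report more compounds than this note shows. Statements on the series, on what has been measured and on what is new or still open speak of the compounds shown alone.

Measured so far in an assay on cells for inhibition of Amine oxidase [flavin-containing] B (Homo sapiens), read by fluorescence and spectrophotometry, using microsomes, with a stated time of 20 min; a higher number here means a weaker inhibitor, a lower number a stronger inhibitor:
compound 1 `NS(=O)(=O)c1ccc(-c2nnc(-c3ccc(Cl)c(Cl)c3)o2)cc1` gives 2.7 nM;
compound 2 `NS(=O)(=O)c1ccc(-c2nnc(-c3ccc(Cl)cc3)o2)cc1` gives 48 nM.

On these two numbers, compound 2 stands at the high end: the step of an 18-fold higher number from compound 1 to compound 2 (1.25 log units; beyond the scatter) shows that taking one chloro away already gave a much weaker inhibitor. Compound 3 `NS(=O)(=O)c1ccc(-c2nnc(-c3ccccc3)o2)cc1` is the next cut in the same direction, (hydrogen in place of chloro on an aromatic carbon), which removes the last chloro. Among the measured compounds shown here, the only measured step that bears on it is the one from compound 1 to compound 2, and it was large; a further loss is therefore expected in this assay, probably also beyond the scatter, though the size is uncertain. Compound 3 is estimated at 300 nM (range 80 nM to 1500 nM), a step of a 6.3-fold higher number from compound 2 to compound 3 (0.80 log units; beyond the scatter).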

Compound 3, half-maximal inhibitory concentration: 168 nM
Estimate against measurement, compound 3: 1.8-fold (0.25 log units) above; measured number inside the range.
By their numbers in this assay, from the lowest: compound 1; then compound 2; then compound 3.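

In this assay, among the compounds shown here, the 4-chlorophenyl to phenyl change still weakens inhibition, with a 3.5-fold higher number from compound 2 to compound 3 (0.54 log units; beyond the scatter) as the measured step, so the single chloro left on compound 2 still counts. This modest step stands against the large one for the first chloro removed, an 18-fold higher number from compound 1 to compound 2 (1.25 log units; beyond the scatter) as printed, so in these three compounds the two chloro groups do not count equally. Nothing shown here explains either loss.

As far as these compounds go, whether fluoro, methoxy or an amine at this place would match chloro remains open. So does how a lone chloro would behave at the other ring position that compound 1 carries.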